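The source may report more compounds than this note shows. Statements on the series, on what has been measured and on what is new or still open speak of the compounds shown alone.

Going by the values given here, compound 2 `COc1ccccc1NC1=CC(=O)c2nc3n(c2C1=O)[C@H]1OC[C@@H](O)[C@H]1OC3` gives the lowest of the three numbers so far in a functional assay on HeLa cells (Homo sapiens) for inhibition, read by sulforhodamine B assay (on this read-out lower numbers stand for stronger inhibition and higher numbers for weaker inhibition), with a value of 2950 nM. Compound 3 `CCOc1ccc(NC2=CC(=O)c3nc4n(c3C2=O)[C@H]2OC[C@@H](O)[C@H]2OC4)cc1` stands nearest to it, at 3110 nM in this assay, while compound 1 `CCCc1ccc(NC2=CC(=O)c3nc4n(c3C2=O)[C@H]2OC[C@@H](O)[C@H]2OC4)cc1` gives 4990 nM; the step of a 1.7-fold lower number from compound 1 to compound 2 (0.23 log units; within the scatter) and the step of a 1.1-fold higher number from compound 2 to compound 3 (0.02 log units; within the scatter) both lie within the scatter, as does the step of a 1.6-fold lower number from compound 1 to compound 3 (0.21 log units; within the scatter), so the three compounds cannot be ranked against one another.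

Compound 4 `O=C1C=C(N2CCCC2)C(=O)c2c1nc1n2[C@H]2OC[C@@H](O)[C@H]2OC1` is the next compound, and its change from compound 2 is pyrrolidin-1-yl in place of (2-methoxyphenyl)amino on a double-bonded ring carbon. Among the compounds with values here, none of the measured steps bears on this change: every one of them varied only the group on the aromatic ring while the arylamino link itself was kept, and all three stayed within the scatter. The change to compound 4 removes that ring and the amine hydrogen altogether, and the data give no guide to its effect. The step of a 2.0-fold higher number from compound 2 to compound 4 (0.31 log units; beyond the scatter) is therefore an expectation with little behind it. Compound 4 is estimated at 6000 nM in this assay, within a range from 1500 nM to 25000 nM.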

Compound 4, half-maximal inhibitory concentration: > 16000 nM
Compound 4: only a limit was reported; the forecaster's own chance of this, stated with the estimate: 10%; middle value at least 2.6-fold (0.42 log units) away from the limit.
By their numbers in this assay, from the lowest: compounds 2, 3 and 1 (each within the scatter of the next). At a limit, above all of these: compound 4.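

Among compounds 1, 2 and 3, the steps only varied the aromatic ring and stayed within the scatter, but pyrrolidin-1-yl in place of (2-methoxyphenyl)amino on the double-bonded ring carbon gives an at least 5.4-fold higher number from compound 2 to compound 4 (0.73 log units; beyond the scatter) in this assay, the first step here beyond the scatter. The group at this place therefore matters: this exchange weakens inhibition in a way that no change on the aromatic ring has done. Compound 4 stands at a limit and not at a number: the limit of > 16000 nM in this assay, at which 1 of the 4 values shown sits.

This change removes the aromatic ring and the amine hydrogen together, and the compounds shown cannot tell which loss counts. A cyclopentylamino group, which keeps the amine hydrogen without the aromatic ring, or a (2-methoxyphenyl)(methyl)amino group, which keeps the ring without that hydrogen, would separate the two.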